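A Fluorine Swap and a Methoxy Question in Pancreatic Cells

The compounds below may be only part of what the source reports. "The series", "measured", "known", "first", "only" and "open" are said of these compounds alone.

Measured compounds:
compound 1, `O=C(NCc1cn(Cc2ccc(C(F)(F)F)cc2)nn1)c1cn(-c2ccccc2)nc1-c1ccccc1`, 17700 nM
compound 2, `COc1ccc(Cn2cc(CNC(=O)c3cn(-c4ccccc4)nc3-c3ccccc3)nn2)cc1`, 10200 nM
compound 3, `O=C(NCc1cn(Cc2ccc(C(F)(F)F)cc2)nn1)c1cn(-c2ccccc2)nc1-c1ccc(F)cc1`, 760 nM

All three were tested in a functional assay on MIA PaCa-2 cells (Homo sapiens) for antiproliferative activity, read by sulforhodamine B assay, with a stated time of 48 h; on this read-out lower numbers stand for stronger inhibition of growth and higher numbers for weaker inhibition of growth. Compound 1 and compound 2 share a core and differ at one spot: methoxy in place of trifluoromethyl on an aromatic carbon. That change gave a 1.7-fold lower number from compound 1 to compound 2 (0.24 log units; within the scatter), so the two values cannot be told apart with confidence. Compound 3 differs from compound 1 in its core: fluoro in place of hydrogen on an aromatic carbon. This step was much larger, a 23-fold lower number from compound 1 to compound 3 (1.37 log units; beyond the scatter), and compound 3 has the lowest number of the three, beyond the scatter against both others.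

The unmeasured compound 4, `COc1ccc(Cn2cc(CNC(=O)c3cn(-c4ccccc4)nc3-c3ccc(F)cc3)nn2)cc1`, carries the core of compound 3 and repeats the change seen between compound 1 and compound 2: methoxy in place of trifluoromethyl on an aromatic carbon. The surroundings of the change are the same in both pairs, so it is the same change made on a different core.

Among the measured compounds shown here, the step from compound 3 to compound 4 is expected to resemble the earlier one, roughly a 1.5-fold lower number from compound 3 to compound 4 (0.18 log units; within the scatter), because a 1.7-fold lower number from compound 1 to compound 2 (0.24 log units; within the scatter) was small and within the scatter; there is no second example on this core to test whether the fluorine-bearing core behaves differently. Compound 4 is therefore estimated at 500 nM, likely between 200 nM and 1500 nM.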

Compound 4, concentration for 50% growth inhibition: 3700 nM
Estimate against measurement, compound 4: 7.4-fold (0.87 log units) below, and the stated range ends below it.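

In this assay, methoxy in place of trifluoromethyl did not carry over from one core to the other: on the core of compound 3 it gave a 4.9-fold higher number from compound 3 to compound 4 (0.69 log units; beyond the scatter), a real loss of growth inhibition that the core of compound 1 did not show, and the two steps differ: the same change on two cores in this assay, a 1.7-fold lower number (0.24 log units; within the scatter) from compound 1 to compound 2 and a 4.9-fold higher number (0.69 log units; beyond the scatter) from compound 3 to compound 4, 8.4-fold (0.93 log units) apart, beyond the scatter of two such steps

Read the other way, fluoro in place of hydrogen lowered the number on both cores, with a 2.8-fold lower number from compound 2 to compound 4 (0.44 log units; beyond the scatter), but the size of that gain depended on the group at the far end of the molecule: the same change on two cores in this assay, a 23-fold lower number (1.37 log units; beyond the scatter) from compound 1 to compound 3 and a 2.8-fold lower number (0.44 log units; beyond the scatter) from compound 2 to compound 4, 8.4-fold (0.93 log units) apart, beyond the scatter of two such steps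

These two comparisons rest on the same four compounds, so they are one finding seen from two sides: the two changes do not simply add up here, but nothing shows why, and a single set of four cannot show whether this holds beyond them.

As far as these compounds go, it stays open whether a chloro group or a nitrile in place of trifluoromethyl on the core of compound 3 would behave like compound 3 or like compound 4. Also open, from the compounds shown here alone, is whether a benzyl group with no added substituent would keep the low number of compound 3 or lose it, as the methoxy group did in compound 4.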